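Lengthening the ester chain from ethoxy to propoxy

The source may report more compounds than this note shows. Statements on the series, on what has been measured and on what is new or still open speak of the compounds shown alone.

Values in a functional assay on MDA-MB-231 cells (Homo sapiens) for antiproliferative activity, read by MTT assay, with a stated time of 48 h; on this read-out lower numbers stand for stronger inhibition of growth and higher numbers for weaker inhibition of growth
Compound 1 `CCCOC(=O)N1N=C(c2ccccc2)CC1c1cc(OC)c(OC)c(OC)c1` gives 14400 nM
Compound 2 `COC(=O)N1N=C(c2cccc(OC)c2)CC1c1cc(OC)c(OC)c(OC)c1` gives 350 nM
Compound 3 `CCOC(=O)N1N=C(c2cccc(OC)c2)CC1c1cc(OC)c(OC)c(OC)c1` gives 9100 nM
Compound 4 `CCCOC(=O)N1N=C(c2cccc(OC)c2)CC1c1cc(OC)c(OC)c(OC)c1` is not yet measured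

Compound 3 lies within the scatter of compound 1 and well above compound 2. Compound 4 turns ethoxy into propoxy: methyl in place of hydrogen on a saturated chain carbon, two bonds along the chain from an oxygen next to a carbonyl group. Going by the values given here, the only measured step of this sort is a 26-fold higher number from compound 2 to compound 3 (1.41 log units; beyond the scatter) and it is large. Compound 1 also carries propoxy, with a different group pattern elsewhere, and gives 14400 nM which is within the scatter of compound 3. A further rise in this assay is therefore expected, but only a small one, probably within the scatter. The expected step is a 1.3-fold higher number from compound 3 to compound 4 (0.12 log units; within the scatter). Compound 4 is estimated at 12000 nM with an expected range from 4500 nM to 30000 nM.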

Compound 4, concentration for 50% growth inhibition: 12500 nM
Beside the measured number, compound 4's estimate is 1.0-fold (0.02 log units) below it; low and high end bracket the measured number.
By their numbers in this assay, from the lowest: compound 2; then compounds 3, 4 and 1 (each within the scatter of the next).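

In this assay, the large loss in this series sits at the shortest end of the ester chain: a 36-fold higher number from compound 2 to compound 4 (1.55 log units; beyond the scatter) spans the whole change to propoxy, while going on from ethoxy to propoxy gives only a 1.4-fold higher number from compound 3 to compound 4 (0.14 log units; within the scatter) and adds nothing measurable. With propoxy in both compounds, methoxy in place of hydrogen on an aromatic carbon gives a 1.2-fold lower number from compound 1 to compound 4 (0.06 log units; within the scatter) and does not restore the low number of compound 2. Going by these compounds, whether a longer chain such as butyl, or an amine at the chain end, stays in this high range remains open. Nothing available explains why this chain length matters so sharply.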